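Iodophenyl for Cyclopentyl on a Shared Core

This account rests on a few compounds, and the source may have more. Where it says the series, first, only, none or still open, it means among the compounds named here.

Of the compounds shown here, three have been measured in a functional assay on MCF7 cells (Homo sapiens) for inhibition, read by sulforhodamine B assay; a lower number here means a stronger inhibitor, a higher number a weaker inhibitor. Compound 1 `O=C1C(NC2CCCC2)=CC(=O)c2c1nc1n2[C@H]2OC[C@@H](O)[C@H]2OC1` reaches only the limit of this assay, > 16000 nM, which is a bound rather than a number. Compound 2 `O=C1C(Nc2ccc(Br)cc2)=CC(=O)c2c1nc1n2[C@H]2OC[C@@H](O)[C@H]2OC1` gives 4330 nM in this assay. Going by the values given here, the one change between them brought an at least 3.6-fold lower number from compound 1 to compound 2 (0.56 log units; beyond the scatter), so the aromatic ring in place of the saturated one did strengthen inhibition there. Compound 3 `O=C1C=C(NC2CCCC2)C(=O)c2c1nc1n2[C@H]2OC[C@@H](O)[C@H]2OC1` holds the same groups as compound 1, joined in a different arrangement. Compound 3 also reaches only the limit, > 16000 nM, so nothing more than that bound is known for it. This is the limit of > 16000 nM in this assay, at which 2 of the 3 values shown sit, and it leaves the true starting point for compound 3 open.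

Compound 4 `O=C1C=C(Nc2ccc(I)cc2)C(=O)c2c1nc1n2[C@H]2OC[C@@H](O)[C@H]2OC1` differs from compound 3 in one place: 4-iodophenyl in place of cyclopentyl on an amine nitrogen. Among the compounds with values here, the only measured step that resembles this change is the one from compound 1 to compound 2, where an aromatic halogenated ring replaced cyclopentyl on the amine nitrogen and the number fell beyond the scatter. A fall of similar kind is therefore expected here, though its size cannot be fixed because compound 3 gives only > 16000 nM. Compound 4 is expected to give about 5000 nM in this assay, within 1500 nM to 16000 nM, which would mean an at least 3.2-fold lower number from compound 3 to compound 4 (0.50 log units; beyond the scatter).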

Compound 4, half-maximal inhibitory concentration: 2230 nM
The estimate for compound 4 lay 2.2-fold (0.35 log units) above the measured number, and the stated range covers the measured number.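

In this assay, the change gives an at least 7.1-fold lower number from compound 3 to compound 4 (0.85 log units; beyond the scatter), so swapping cyclopentyl for a halogenated aromatic ring on the amine nitrogen now lowers the number in both arrangements of the shared core shown here. The earlier step, an at least 3.6-fold lower number from compound 1 to compound 2 (0.56 log units; beyond the scatter), showed this in only one arrangement, and compound 4 now shows that the second arrangement can also give a measurable value rather than a limit. Compound 3 stands at a limit rather than a number, so the true size of the new step stays unknown because its starting point is only a bound: the limit of > 16000 nM in this assay, at which 2 of the 4 values shown sit.

Compound 2 and compound 4 differ in both the halogen and the arrangement of the core, so these compounds cannot show whether iodine or bromine is the better choice, or which arrangement is better. Going by these compounds, it also remains open whether the aromatic ring alone accounts for the fall, and a plain phenyl group with no halogen on the same amine nitrogen would separate the ring from the halogen.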